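Swapping a Butylcarbamoyl for a Pyridinylsulfonyl Group

A few compounds are considered here, and "the series" means these few. Any claim that something is new, unique, unknown or untested is made for them only; others in the source may bear on it.

Of the compounds shown here, three sharing one core have been measured in a functional assay for inhibition, with Homo sapiens as the target; on this read-out higher numbers stand for weaker inhibition and lower numbers for stronger inhibition. Compound 1 `CC(C)CS(=O)(=O)N[C@@H](CNC(=O)c1ccc2c(c1)C(=O)N(CCC1CCNCC1)C2)C(=O)O` gives 9 nM. Compound 2 `CCCCCS(=O)(=O)N[C@@H](CNC(=O)c1ccc2c(c1)C(=O)N(CCC1CCNCC1)C2)C(=O)O` gives 9 nM. Compound 3 `CCCCNC(=O)N[C@@H](CNC(=O)c1ccc2c(c1)C(=O)N(CCC1CCNCC1)C2)C(=O)O` gives 16 nM. Compound 3 thus stands within the usual scatter of both neighbours: a 1.8-fold higher number from compound 1 to compound 3 (0.25 log units; within the scatter) and a 1.8-fold higher number from compound 2 to compound 3 (0.25 log units; within the scatter), so no real difference between the three can be claimed.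

Compound 4 `O=C(NC[C@H](NS(=O)(=O)c1cccnc1)C(=O)O)c1ccc2c(c1)C(=O)N(CCC1CCNCC1)C2` is not yet measured. It differs from compound 3 in one place: (pyridin-3-yl)sulfonyl in place of butylcarbamoyl on an amine nitrogen. The change returns the nitrogen to a sulfonyl substituent, as in compound 1 and compound 2, but with a pyridin-3-yl ring where those carry a chain.

Two kinds of measured step bear on this. Exchanging a sulfonyl for a carbamoyl on this nitrogen left the number unchanged within the scatter, as a 1.8-fold higher number from compound 1 to compound 3 (0.25 log units; within the scatter) and a 1.8-fold higher number from compound 2 to compound 3 (0.25 log units; within the scatter) show. Changing the group on the sulfonyl sulfur also did nothing: no change at the digits printed from compound 1 to compound 2 (within the scatter). Among the compounds with values here, no measured compound carries an aromatic ring at this position, so the effect of the ring itself is untested.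

Compound 4 is therefore expected to stay close to its neighbours, with an estimated step of a 1.5-fold lower number from compound 3 to compound 4 (0.16 log units; within the scatter). The estimate for compound 4 is 11 nM, within a range of 4 nM to 30 nM.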

Compound 4, half-maximal inhibitory concentration: 15 nM
The estimate for compound 4 lay 1.4-fold (0.13 log units) below the measured number, and the stated range covers the measured number.
By their numbers in this assay, from the lowest: compounds 1, 2, 4 and 3 (each within the scatter of the next).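

In this assay, within the data shown here, this result is the first test of an aromatic ring at this position, and putting (pyridin-3-yl)sulfonyl in place of butylcarbamoyl on the amine nitrogen gives a 1.1-fold lower number from compound 3 to compound 4 (0.03 log units; within the scatter) as its step. On the sulfonyl sulfur, pyridin-3-yl in place of pentyl gives a 1.7-fold higher number from compound 2 to compound 4 (0.22 log units; within the scatter) and pyridin-3-yl in place of isobutyl gives a 1.7-fold higher number from compound 1 to compound 4 (0.22 log units; within the scatter) so that, among these four compounds, a six-membered aromatic ring with one hetero atom cannot be told apart from either saturated chain, and the nitrogen has now carried chains, a ring and a carbamoyl without a step beyond the scatter. No measurement at hand explains why these changes leave the number so flat.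

Still open, from the compounds shown here alone, is whether the number would stay in this range with a free amine on this nitrogen, or with a phenyl or a much larger two-ring aromatic group on the sulfonyl sulfur. The compounds shown also leave open what would happen if a methyl ester took the place of the carboxylic acid, since all four carry that acid unchanged.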